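The compounds below may be only part of what the source reports. "The series", "measured", "known", "first", "only" and "open" are said of these compounds alone.

Of the compounds shown here, two with a shared core have been measured in a functional assay on AGS cells (Homo sapiens) for antiproliferative activity, read by CCK-8 assay, with a stated time of 72 h; on this read-out lower numbers stand for stronger inhibition and higher numbers for weaker inhibition. Compound 1 `O=C(Nc1ccc(-c2cnc3cc(Br)ccn23)cc1)c1ccc([N+](=O)[O-])o1` gives 560 nM in this assay. Compound 2 `COc1ccn2c(-c3ccc(NC(=O)c4ccc([N+](=O)[O-])o4)cc3)cnc2c1` gives 720 nM in this assay. Within the data shown here, the only step measured so far, a 1.3-fold higher number from compound 1 to compound 2 (0.11 log units; within the scatter), concerns a different position from the one now changed. Compound 2 carries the higher of the two numbers, yet its distance to compound 1 lies within the scatter, so the two compounds cannot be told apart on these data. Compound 3 `COc1ccn2c(-c3ccc(NC(=O)c4ccc([N+](=O)[O-])o4)cc3F)cnc2c1` has not yet been measured; it differs from compound 2 by fluoro in place of hydrogen on an aromatic carbon. Among the measured compounds shown here, no measured step bears on this change, because the one step available, a 1.3-fold higher number from compound 1 to compound 2 (0.11 log units; within the scatter), swaps groups at another carbon and itself stayed within the scatter. Without a comparable step, no shift beyond the scatter is expected in this assay, so compound 3 is estimated at 700 nM, with a range from 300 nM to 1600 nM, which means an expected step of a 1.0-fold lower number from compound 2 to compound 3 (0.01 log units; within the scatter).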

Compound 3, half-maximal inhibitory concentration: 700 nM
The estimate for compound 3 equals the measured number at the digits printed, and the stated range covers the measured number.
By their numbers in this assay, from the lowest: compounds 1, 3 and 2 (each within the scatter of the next).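

Fluoro in place of hydrogen, on an aromatic carbon of a six-membered aromatic ring of carbon only, ortho to a large group and meta to a large group, gives a 1.0-fold lower number from compound 2 to compound 3 (0.01 log units; within the scatter) in this assay. Among these compounds, this is the first reading at this position, and it shows that the position accepts a single fluorine atom with no change that can be told from the scatter. Compound 3 therefore cannot be separated from compound 2 on these data, and no measurement on hand offers an explanation for this outcome.

On these data alone, whether an amine, a carboxylic acid or a longer chain on the same carbon would move the number beyond the scatter remains open. As far as these compounds go, whether the fluoro change would read the same on compound 1, which carries bromo rather than methoxy, also remains open.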